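The source may hold more compounds than are shown below. What is called first, only, known or untested is meant among the compounds shown, and "the series" means these compounds.

Of the compounds shown here, two from this series have been measured in an ADME assay on MCF-10A cells (Homo sapiens) for cytotoxicity, with a stated time of 72 h (on this read-out lower numbers stand for an effect already at smaller amounts and higher numbers for an effect only at larger amounts of compound), so far. Compound 1 `COC(=O)c1ccc(N(Cc2cnc(C3CCCCC3)cn2)C(=O)[C@H]2CCN2S(=O)(=O)c2c(F)c(F)c(F)c(F)c2F)c(F)c1` gives 4000 nM in this assay. Compound 2 `O=C1OCc2cc(N(Cc3ccc(C4CCCCC4)cn3)C(=O)[C@H]3CCN3S(=O)(=O)c3c(F)c(F)c(F)c(F)c3F)ccc21` gives 4600 nM in this assay; its number is the higher of the two, yet the gap to compound 1 lies within the scatter of repeated measurements, so the two compounds cannot be told apart on these data.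

Compound 3 `O=C1NC(=O)c2cc(N(Cc3ccc(C4CCCCC4)cn3)C(=O)[C@H]3CCN3S(=O)(=O)c3c(F)c(F)c(F)c(F)c3F)ccc21` has not yet been measured. It differs from compound 2 in one place: a group of 11 heavy atoms (8 carbon, 1 nitrogen, 2 oxygen; one five-membered non-aromatic ring with 1 hetero atom, one six-membered aromatic ring of carbon only) in place of a group of 10 heavy atoms (8 carbon, 2 oxygen; one five-membered non-aromatic ring with 1 hetero atom, one six-membered aromatic ring of carbon only), on an amide-type nitrogen. The group that enters carries one hydrogen-bond donor where the leaving group has none, and the change sits on an amide-type nitrogen.

Among the measured compounds shown here, no measured pair in this set shows how such a change moves this assay. The step of a 1.0-fold lower number from compound 2 to compound 3 (0.01 log units; within the scatter) is therefore expected to stay within the scatter, without a clear direction. Compound 3 is estimated at 4500 nM, with a range from 2000 nM to 10000 nM.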

Compound 3, half-maximal effective concentration: 8100 nM
For compound 3 the middle estimate is 1.8-fold (0.26 log units) below the measured one, and the stated range covers the measured number.
By their numbers in this assay, from the lowest: compounds 1, 2 and 3 (each within the scatter of the next, the first and the last beyond it).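

On the amide-type nitrogen, the group of 11 heavy atoms, which carries a hydrogen-bond donor, in place of the group of 10 heavy atoms, which carries none, gives a 1.8-fold higher number from compound 2 to compound 3 (0.25 log units; within the scatter) in this assay. Among the compounds shown here, this is the first measured step at this place, and it shows that bringing in the hydrogen-bond donor together with the added double bond does not move the number beyond the scatter, so compound 2 and compound 3 cannot be told apart on this read-out. Nothing measured here bears on this step.

For the compounds shown here, with only one step at this place, the effect of the hydrogen-bond donor cannot be separated from that of the added double bond. As far as these compounds go, how a group with an amine or a carboxylic acid on this amide-type nitrogen would read in this assay remains open.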